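Phenoxy in Place of Bromo Across Two Related Cores

This account rests on a few compounds, and the source may have more. Where it says the series, first, only, none or still open, it means among the compounds named here.

Compound 1 `Cc1ccc(S/C(=C/c2ccc(Br)cc2)C(=O)c2ccc(Cl)cc2)cc1` and compound 3 `Cc1ccc(S/C(=C/c2ccc(Oc3ccccc3)cc2)C(=O)c2ccc(Cl)cc2)cc1` share one core; in a functional assay on DU-145 cells (Homo sapiens) for inhibition, read by trypan blue exclusion, with a stated time of 96 h (on this read-out higher numbers stand for weaker inhibition of growth and lower numbers for stronger inhibition of growth), compound 1 gives 25000 nM and compound 3 gives 10000 nM. The change between them, (phenoxy in place of bromo on an aromatic carbon), made a step of a 2.5-fold lower number from compound 1 to compound 3 (0.40 log units; beyond the scatter). Compound 2 `O=C(/C(=C\c1ccc(Br)cc1)Sc1ccc(Br)cc1)c1ccc(Br)cc1` has a core whose difference from compound 1 is not broken down here; in this assay compound 2 gives 1000 nM, the lowest of the three numbers. Compound 4 `O=C(/C(=C\c1ccc(Oc2ccccc2)cc1)Sc1ccc(Br)cc1)c1ccc(Br)cc1` is derived from compound 2 by the same change, (phenoxy in place of bromo on an aromatic carbon). Resting on a 2.5-fold lower number from compound 1 to compound 3 (0.40 log units; beyond the scatter), the step from compound 2 to compound 4 in this assay is expected to be a 2.2-fold lower number from compound 2 to compound 4 (0.35 log units; beyond the scatter). Compound 4 is therefore estimated at 450 nM in this assay, likely between 150 nM and 1500 nM.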

Compound 4, concentration for 50% growth inhibition: 50000 nM
Beside the measured number, compound 4's estimate is 110-fold (2.05 log units) below it; measured number outside the range, above it.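

In this assay, phenoxy in place of bromo gave a 50-fold higher number from compound 2 to compound 4 (1.70 log units; beyond the scatter), so the change did not carry from the core of compound 1 to the core of compound 2, and its direction reversed: the same change on two cores in this assay, a 2.5-fold lower number (0.40 log units; beyond the scatter) from compound 1 to compound 3 and a 50-fold higher number (1.70 log units; beyond the scatter) from compound 2 to compound 4, 130-fold (2.10 log units) apart, beyond the scatter of two such steps In this series, the step seen on one core therefore cannot be relied on to predict the step on the other. These two pairs do not show which difference between the cores is responsible, nor how the change would behave on any further core.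

From the compounds shown here alone, it remains open whether a methoxy group or an amine in the same place would follow compound 3 or compound 4. Also open, going by these compounds, is which of the methyl and chloro groups of compound 1, set against the bromo groups of compound 2, governs the reversal.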